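Inverting one ring stereocentre in a sugar-like aminoalcohol

The source may report more compounds than this note shows. Statements on the series, on what has been measured and on what is new or still open speak of the compounds shown alone.

Three compounds share a small oxygen-containing ring carrying an amine, a hydroxyl and an alkylamine-bearing arm. Compound 1 `CCCCCCCCCCCNC[C@@H]1OC[C@H](N)[C@H]1O` and compound 2 `CCCCCCCCNC[C@@H]1OC[C@H](N)[C@H]1O` differ in chain length, and compound 3 `CCCCCCCCCNC[C@@H]1OC[C@H](N)[C@@H]1O` has a nine-carbon chain. In a functional assay on B16-F10 cells (Mus musculus) for antiproliferative activity, read by MTT assay, with a stated time of 72 h (a higher number here means a weaker inhibitor, a lower number a stronger inhibitor), compound 1 gives 88800 nM. In this assay compound 2 reaches only a limit, > 128000 nM. In this assay compound 3 gives 55200 nM, the lower of the two numbers, though its gap to compound 1 lies within the scatter.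

The unmeasured compound 4 `CCCCCCCCCNC[C@@H]1OC[C@H](N)[C@H]1O` differs from compound 3 as follows: the two compounds have the same atoms and bonds and differ only in configuration as drawn: 1 of 3 stereo elements differ; a stereocentre at a saturated ring carbon is drawn S in compound 3 and R in compound 4.

Within the data shown here, the only measured step, an at least 1.4-fold higher number from compound 1 to compound 2 (0.15 log units; that floor lies within the scatter), concerns the chain and not the configuration, so no measured step bears on this change. With no evidence on how inverting this centre acts, the expected step of a 1.4-fold higher number from compound 3 to compound 4 (0.13 log units; within the scatter) is centred near no change but spans a wide range. Compound 4 is therefore estimated at 75000 nM, with a range from 28000 nM to 200000 nM.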

Compound 4, half-maximal inhibitory concentration: > 128000 nM
Compound 4: a limit, no number (the forecaster's own chance of this, stated with the estimate: 30%); middle value at least 1.7-fold (0.23 log units) from the limit.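

Inverting this one centre gives an at least 2.3-fold higher number from compound 3 to compound 4 (0.36 log units; beyond the scatter) in this assay, the first step shown whose size goes beyond the scatter. That step can be tied to the configuration at this saturated ring carbon alone, because nothing else differs: the fact that compounds 3 and 4 differ only in the configuration as drawn. By contrast, an at least 1.4-fold higher number from compound 1 to compound 4 (0.15 log units; that floor lies within the scatter) is only a floor, and the step from compound 2 to compound 4 cannot be read.

From the compounds shown here alone, compound 4 is a limit and not a number, so how much the inversion costs in full stays open: the limit of > 128000 nM in this assay, at which 2 of the 4 values shown sit. Also open, going by these compounds, is whether the same inversion matters as much with a longer chain, such as dodecyl, or with an acetamide in place of the amine.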